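The source may hold more compounds than are shown below. What is called first, only, known or untested is meant among the compounds shown, and "the series" means these compounds.

Compounds measured so far:
Compound 1, `COc1cc(C(c2ccc(O)c(OC)c2)[C@H](C)[C@H](C)CO)ccc1O`, > 100000 nM (a limit of the assay)
Compound 2, `COC[C@H](C)[C@@H](C)C(c1ccc(O)c(OC)c1)c1ccc(O)c(OC)c1`, 77000 nM
Compound 3, `COc1cc(C(c2ccc(O)c(OC)c2)[C@@H](C)[C@H](C)CO)ccc1O`, > 100000 nM (a limit of the assay)

In a functional assay on HeLa cells (Homo sapiens) for cytotoxicity, read by WST assay, with a stated time of 48 h (on this read-out higher numbers stand for weaker inhibition and lower numbers for stronger inhibition), compound 1 gives only a limit of the assay, > 100000 nM. The same holds for compound 3, which in this assay gives > 100000 nM, also a limit. Compound 2 is the one of the three that gives a number in this assay, 77000 nM. The step of an at least 1.2-fold lower number from compound 1 to compound 2 (0.11 log units; that floor lies within the scatter) is the closest guide, and the step of an at least 1.2-fold higher number from compound 2 to compound 3 (0.11 log units; that floor lies within the scatter) runs the other way by the same small margin; because of the limit of > 100000 nM in this assay, at which 2 of the 3 values shown sit, neither can be read as more than a floor. The step that the two limits leave unreadable from compound 1 to compound 3 cannot be read either, because the fact that compounds 1 and 3 differ only in the configuration as drawn leaves both ends as limits. Compound 4, `COC[C@@H](C)[C@H](C)C(c1ccc(O)c(OC)c1)c1ccc(O)c(OC)c1`, carries the change (2-(methoxymethyl)-1-methylpropyl in place of 2-(hydroxymethyl)-1-methylpropyl on a saturated chain carbon bound to two aromatic carbons). On this evidence the step of an at least 1.2-fold lower number from compound 1 to compound 4 (0.09 log units; that floor lies within the scatter) is expected to be small, within the scatter, and compound 4 is estimated at 80000 nM, between 40000 nM and 160000 nM.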

Compound 4, half-maximal inhibitory concentration: 58000 nM
Compound 4: middle estimate off by 1.4-fold (0.14 log units), on the high side; low and high end bracket the measured number.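

In this assay, both mirror-image compounds carrying 2-(methoxymethyl)-1-methylpropyl now give measured numbers, and the step between them is a 1.3-fold lower number from compound 2 to compound 4 (0.12 log units; within the scatter). Measured against the hydroxymethyl compounds, which sit at a limit of the assay, the steps can be read only as floors: an at least 1.7-fold lower number from compound 1 to compound 4 (0.23 log units; that floor lies within the scatter) and an at least 1.7-fold lower number from compound 3 to compound 4 (0.23 log units; that floor lies within the scatter), so neither shows a change beyond the scatter. The comparison of the two measured compounds therefore concerns stereochemistry alone, and inverting both stereocentres leaves no separation beyond the scatter: the fact that compounds 2 and 4 differ only in the configuration as drawn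

The step between the two hydroxymethyl compounds remains unreadable, since both ends are limits of the assay. From the compounds shown here alone, it also remains open whether a longer ether such as ethoxymethyl, or an aminomethyl group, at this position would move the number beyond the scatter.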